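A few compounds are considered here, and "the series" means these few. Any claim that something is new, unique, unknown or untested is made for them only; others in the source may bear on it.

Compound 1, `CC1(C)CCOc2ccc(NC(=O)Nc3ccc([N+](=O)[O-])cc3)cc21`: 6700 nM in a functional assay on A2780 cells (Homo sapiens) for inhibition, with a stated time of 72 h; a higher number here means a weaker inhibitor, a lower number a stronger inhibitor.
Compound 2, `CC1(C)CC(C)(C)c2cc(NC(=O)Nc3ccc(OC(F)(F)F)cc3)ccc2O1`: 4560 nM in this assay.

For the measured compounds named here, compound 1 holds the higher of the two numbers so far recorded, but the value of compound 2 sits within the usual scatter of it, so the two compounds cannot be ranked against each other on these data. Compound 3, `CC1(C)CCOc2ccc(NC(=O)Nc3ccc(C(F)(F)F)cc3)cc21`, has not yet been measured in this assay. It differs from compound 1 in one place: trifluoromethyl in place of nitro on an aromatic carbon. Going by the values given here, no pair of measured compounds differs in exactly this way, so no measured step is available for this exchange. Compound 2 carries yet another group on that ring and a different core, so its value says nothing direct about the change from nitro to trifluoromethyl. The expectation therefore rests on compound 1 alone: the step from compound 1 to compound 3 in this assay is expected to be a 1.2-fold lower number from compound 1 to compound 3 (0.09 log units; within the scatter), small and not beyond the scatter. Compound 3 is estimated at 5500 nM, with a range from 2000 nM to 15000 nM.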

Compound 3, half-maximal inhibitory concentration: 5000 nM
Compound 3: middle estimate off by 1.1-fold (0.04 log units), on the high side, and the stated range covers the measured number.
By their numbers in this assay, from the lowest: compounds 2, 3 and 1 (each within the scatter of the next).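

On the core of compound 1, at the place on an aromatic carbon of a six-membered aromatic ring of carbon only, para to a large group, the exchange of nitro for trifluoromethyl now has a measured step: a 1.3-fold lower number from compound 1 to compound 3 (0.13 log units; within the scatter) in this assay. The earlier compounds shown here offered no such pair, and this one shows that the two groups cannot be told apart here, even though nitro, with 2 hydrogen-bond acceptors and 1 double bond outside aromatic rings, gives way to trifluoromethyl, with 0 hydrogen-bond acceptors and no such double bond. No measurement of any property of these two groups accompanies this result, so the data offer no explanation for it.

From the compounds shown here alone, whether a group of another kind at this place, such as an amine, a carboxylic acid or a longer alkyl chain, would give a step beyond the scatter remains open. This single step also stands on the core of compound 1 alone, and whether the same exchange would read the same way on a different core is equally unsettled.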